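Cyano to methyl on the hydroxyphenyl ring: solubility

A few compounds are considered here, and "the series" means these few. Any claim that something is new, unique, unknown or untested is made for them only; others in the source may bear on it.

Working notes on two analogues of the shared core, compound 1 `Cc1ccccc1N1C(=O)/C(=C/c2ccc(O)c(Cl)c2)S/C1=N\CCO` and compound 2 `CCC/N=C1\S/C(=C\c2ccc(O)c(C#N)c2)C(=O)N1c1ccccc1C`. In a physicochemical assay for solubility, measured as kinetic solubility (a lower number here means a less soluble compound, a higher number a more soluble compound), compound 1 gives a limit of the assay, > 250000 nM, and not a number; this is the limit of > 250000 nM in this assay, at which 1 of the 2 values shown sits. Among the compounds with values here, compound 2 reaches 220000 nM in this assay, the only numerical value in hand. Compound 3 `CCC/N=C1\S/C(=C\c2ccc(O)c(C)c2)C(=O)N1c1ccccc1C` has not been measured; it differs from compound 2 as follows: methyl in place of cyano on an aromatic carbon. Within the data shown here, no step between two measured compounds is available at this position, so the expectation rests on the single value of compound 2. For compound 3 a downward step from compound 2, modest at most, is expected: a 1.5-fold lower number from compound 2 to compound 3 (0.17 log units; within the scatter). Compound 3 is therefore estimated at 150000 nM in this assay, within a range from 60000 nM to 250000 nM.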

Compound 3, solubility: 78000 nM
Beside the measured number, compound 3's estimate is 1.9-fold (0.28 log units) above it; the measured number falls inside the stated range.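

In this assay, within the data shown here, methyl in place of cyano on an aromatic carbon ortho to a hydroxy group gives a 2.8-fold lower number from compound 2 to compound 3 (0.45 log units; beyond the scatter), the first step at this position that can be read. The earlier compounds shown here offered no such pair, and this one shows that, with the rest of the molecule unchanged, the group on this carbon moves the read-out beyond the scatter. Nothing shown gives a measured property that would account for the step.

One pair cannot tell whether the step follows the arrival of methyl or the departure of cyano, or how far it would carry to other groups. A methoxy group, an amine or a carboxylic acid on this aromatic carbon would test whether the read-out tracks the group more generally.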